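The source may report more compounds than this note shows. Statements on the series, on what has been measured and on what is new or still open speak of the compounds shown alone.

Compound 3 `O=C(COc1c(-c2ccccc2)oc2ccccc2c1=O)Nc1ccc(F)cc1` is tested in a functional assay on NPC-TW01 cells (Homo sapiens) for antiproliferative activity, read by MTT assay, with a stated time of 72 h (on this read-out lower numbers stand for stronger inhibition of growth and higher numbers for weaker inhibition of growth), where compound 3 gives 9500 nM. Of the two numbers reported, this one sits at the upper end, but its nearest neighbour, compound 1 `O=C(COc1c(-c2ccccc2)oc2ccccc2c1=O)Nc1ccc2ccccc2c1`, gives 6520 nM, and the step of a 1.5-fold higher number from compound 1 to compound 3 (0.16 log units; within the scatter) stays within the scatter. Compound 2 `O=C(COc1ccc2c(=O)cc(-c3ccccc3)oc2c1)Nc1ccc2ccccc2c1` is recorded only as a limit, > 10000 nM. That limit is the limit of > 10000 nM in this assay, at which 1 of the 3 values shown sits. Compound 4 `O=C(COc1c(-c2ccccc2)oc2ccccc2c1=O)Nc1ccc(-c2ccccc2)cc1` differs from compound 3 in one place: phenyl in place of fluoro on an aromatic carbon. Going by the values given here, the only measured step that touches this region is a 1.5-fold higher number from compound 1 to compound 3 (0.16 log units; within the scatter), which exchanged the whole group on the amide nitrogen, and its size was within the scatter. A step within the scatter is therefore expected, a 1.4-fold lower number from compound 3 to compound 4 (0.13 log units; within the scatter). Compound 4 is estimated at 7000 nM, within a range from 2500 nM to 20000 nM.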

Compound 4, concentration for 50% growth inhibition: > 10000 nM
Compound 4: no number, only a limit; the forecaster's own chance of this, stated with the estimate: 30%; at least 1.4-fold (0.15 log units) between middle value and limit.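

For compound 4, this assay records only a limit, so the true size of the change cannot be fixed. Phenyl in place of fluoro on this aromatic carbon gives an at least 1.0-fold higher number from compound 3 to compound 4 (0.02 log units; that floor lies within the scatter), so the added ring shows no sign of stronger inhibition of growth. Compound 4 now shares its limit with compound 2: the limit of > 10000 nM in this assay, at which 2 of the 4 values shown sit.

From the compounds shown here alone, whether an amine or a carboxylic acid on this carbon would give a number clearly apart from that of compound 3 stays open. Going by these compounds, the actual number for compound 4 also stays unknown.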